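A few compounds are considered here, and "the series" means these few. Any claim that something is new, unique, unknown or untested is made for them only; others in the source may bear on it.

Compound 1 `CCc1cccc2c(OC)c(-c3occ(C)c3CO)ccc12` is the reference point. In a functional assay on SK-BR-3 cells (Homo sapiens) for cytotoxicity, read by MTT assay, with a stated time of 72 h (a higher number here means that more compound is needed for the effect, a lower number that less compound is needed), compound 1 gives 0.73 ug/mL. Compound 2 `CCOc1c(-c2occ(C)c2CO)ccc2c(CC)cccc12` carries methyl in place of hydrogen on a saturated chain carbon bound to an oxygen on an aromatic ring and in this assay compound 2 gives 8.8 ug/mL; the step is a 12-fold higher number from compound 1 to compound 2 (1.08 log units; beyond the scatter). Compound 3 `CCc1cccc2c(OC)c(-c3occ(C)c3COC)ccc12` carries methyl in place of hydrogen on an oxygen on a saturated carbon relative to compound 1. In this assay compound 3 reaches only a limit, > 10 ug/mL, not a number; the step is an at least 13-fold higher number from compound 1 to compound 3 (1.13 log units; beyond the scatter), and the limit is the limit of > 10 ug/mL in this assay, at which 1 of the 3 values shown sits. Compound 4 `CCOCc1c(C)coc1-c1ccc2c(CC)cccc2c1OC` is still unmeasured; it differs from compound 3 by methyl in place of hydrogen on a saturated chain carbon bound to an oxygen on a saturated carbon, the same kind of change as methyl in place of hydrogen on a saturated chain carbon bound to an oxygen on an aromatic ring, though here the place is a saturated chain carbon bound to an oxygen on a saturated carbon rather than to an oxygen on an aromatic ring. The two cores differ by methyl in place of hydrogen on an oxygen on a saturated carbon. Since compound 3 already sits at a limit and the earlier change gave a 12-fold higher number from compound 1 to compound 2 (1.08 log units; beyond the scatter), compound 4 is expected to remain at or beyond that limit, a step that the limit leaves unreadable from compound 3 to compound 4. Compound 4 is estimated at 30 ug/mL, between 10 ug/mL and 100 ug/mL.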

Compound 4, concentration for half-maximal effect: > 10 ug/mL
Compound 4: only a limit was reported; the forecaster's own chance of this, stated with the estimate: 90%; the middle value does not contradict the limit.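

In this assay compound 4 reaches only a limit, > 10 ug/mL, not a number. The change from methoxymethyl to ethoxymethyl cannot be read on this core, because compound 3 and compound 4 both stand at the limit: the limit of > 10 ug/mL in this assay, at which 2 of the 4 values shown sit.
So the step on the core of compound 1, a 12-fold higher number from compound 1 to compound 2 (1.08 log units; beyond the scatter), is neither confirmed nor contradicted on the second core, and the one readable new result is an at least 13-fold higher number from compound 1 to compound 4 (1.13 log units; beyond the scatter), a step in which the hydrogen on the oxygen gives way to ethyl.

Only compound 1 and compound 2, both with hydrogen on that oxygen, give numbers here. Still open, on these data alone, is how an amine or a carboxylic acid at that place would read, or a longer chain on the oxygen on the aromatic ring.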